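This account rests on a few compounds, and the source may have more. Where it says the series, first, only, none or still open, it means among the compounds named here.

Measured in an ADME assay on NHDF cells (Homo sapiens) for cytotoxicity, read by MTT assay, with a stated time of 72 h; on this read-out lower numbers stand for stronger inhibition and higher numbers for weaker inhibition:
- compound 1 `COc1cccc(/C=C2\CCC/C(=C\c3cccc(Br)c3)C2=O)c1OC`: 23900 nM
- compound 2 `COc1ccc(/C=C2\CCC/C(=C\c3cccc(OC)c3OC)C2=O)cc1`: 43500 nM
- compound 3 `COc1cccc(/C=C2\CCC/C(=C\c3cccc(O)c3)C2=O)c1OC`: 19300 nM

Compound 3, at 19300 nM, cannot be told apart from its bromo-bearing relative, as a 1.2-fold lower number from compound 1 to compound 3 (0.09 log units; within the scatter) shows. The methoxy-bearing relative stands further off, with a 2.3-fold lower number from compound 2 to compound 3 (0.35 log units; beyond the scatter).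

Compound 4 `COc1cccc(/C=C2\CCC/C(=C\c3ccc(O)c(Cl)c3)C2=O)c1OC` alters the same part of the molecule as these comparisons: 3-chloro-4-hydroxyphenyl in place of 3-hydroxyphenyl on a double-bonded chain carbon bound to a double-bonded ring carbon. The change sits on a double-bonded chain carbon bound to a double-bonded ring carbon.

For the measured compounds named here, all the measured steps fall at this place. Besides the two above, there is a 1.8-fold higher number from compound 1 to compound 2 (0.26 log units; within the scatter). Even the largest of them is modest, and swapping bromo for hydroxy in compound 1 gave a step within the scatter. Going by the values given here, no measured compound carries chloro and hydroxy together on one ring, so the guide is only indirect.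

No step beyond the scatter is therefore expected in this assay. The estimated change is a 1.1-fold lower number from compound 3 to compound 4 (0.03 log units; within the scatter). Compound 4 is expected at about 18000 nM, within an estimated range of 8000 nM to 40000 nM.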

Compound 4, half-maximal inhibitory concentration: 39500 nM
Compound 4: the middle estimate sits 2.2-fold (0.34 log units) below what was measured; low and high end bracket the measured number.
By their numbers in this assay, from the lowest: compounds 3, 1, 4 and 2 (each within the scatter of the next, the first and the last beyond it).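

In this assay, this place on the molecule now gives a step beyond the scatter, though a modest one: a 2.0-fold higher number from compound 3 to compound 4 (0.31 log units; beyond the scatter). Compound 4 nevertheless stays within the scatter of the other two compounds, with a 1.1-fold lower number from compound 2 to compound 4 (0.04 log units; within the scatter) and a 1.7-fold higher number from compound 1 to compound 4 (0.22 log units; within the scatter), so only its gap to compound 3 can be read as a real difference. No supporting data bear on why the number rose.

The step from 3-hydroxyphenyl to 3-chloro-4-hydroxyphenyl both adds chloro and changes the number at which hydroxy is named, so these compounds cannot separate the two changes. Also open, going by these compounds, is how this assay would respond to an amine or a carboxylic acid on the ring at this place.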